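From Fluoro to Acetyl: Predicting Compound 4

A few compounds are considered here, and "the series" means these few. Any claim that something is new, unique, unknown or untested is made for them only; others in the source may bear on it.

Values from a functional assay (Nicotiana tabacum); on this read-out higher numbers stand for weaker inhibition and lower numbers for stronger inhibition
Compound 1 `CCCCCNc1nc(SC)nc2ncccc12` gives 650 nM
Compound 2 `CCCCCCNc1nc(SC)nc2ncccc12` gives 3330 nM
Compound 3 `CSc1nc(Nc2ccc(F)cc2)c2cccnc2n1` gives 2620 nM

Compound 3, at 2620 nM, cannot be told apart from compound 2, at 3330 nM, as the two lie within the usual scatter of repeated measurements. Compound 1, at 650 nM, has a lower number beyond that scatter, which means stronger inhibition.

Compound 4 `CSc1nc(Nc2ccc(C(C)=O)cc2)c2cccnc2n1` keeps the shared core of compound 3 and differs in one place, with acetyl in place of fluoro on an aromatic carbon, para to a large group (acetyl in place of fluoro on an aromatic carbon).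

Among the compounds with values here, only one measured step exists, a 5.1-fold higher number from compound 1 to compound 2 (0.71 log units; beyond the scatter). It is a methyl in place of hydrogen on a saturated chain carbon, so it is a different change in a different place and bears on this question only indirectly. It does show that one small change can shift the number in this assay by a modest step. Within the data shown here, no measured pair tests a replacement of the fluoro, so the data give no direction.

The expected change is a 1.1-fold higher number from compound 3 to compound 4 (0.06 log units; within the scatter), an estimate that stays within the scatter. For compound 4 the estimated value is 3000 nM, with an expected range from 900 nM to 10000 nM.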

Compound 4, half-maximal inhibitory concentration: 8960 nM
Estimate against measurement, compound 4: 3.0-fold (0.48 log units) below; the range from low to high includes it.
By their numbers in this assay, from the lowest: compound 1; then compounds 3 and 2 (each within the scatter of the next); then compound 4.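

Replacing fluoro with acetyl on an aromatic carbon, para to a large group, gives a 3.4-fold higher number from compound 3 to compound 4 (0.53 log units; beyond the scatter) in this assay, which means weaker inhibition. Within the data shown here, this is the first measured change at this place, and it gives a direction that the earlier compounds could not: here, the larger group goes with the weaker result, although a single pair cannot establish a general trend. The swap brings in more heavy atoms, a double bond outside the aromatic ring and a hydrogen-bond acceptor, but nothing measured here separates these differences or explains the shift.

From the compounds shown here alone, with only fluoro and acetyl to compare at this place, it remains open whether a chlorine atom, a methoxy group, an amine or a carboxylic acid would give a number closer to that of compound 3 or that of compound 4. Going by these compounds, it is also open whether an acetyl group on another carbon of the same ring would shift the number in the same direction, or by a similar amount.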